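Swapping the Sulfonamide Aryl Group in Nicotinamide Phosphoribosyltransferase Inhibitors

This account rests on a few compounds, and the source may have more. Where it says the series, first, only, none or still open, it means among the compounds named here.

Measured compounds:
- compound 1, `O=C(/C=C/c1cccnc1)NCCCCCCCc1cccc(S(=O)(=O)Nc2ccccc2)c1`: 31.3 nM
- compound 2, `Cc1ccccc1NS(=O)(=O)c1cccc(CCCCCCNC(=O)/C=C/c2cccnc2)c1`: 5.08 nM

Both compounds were tested in an assay on isolated protein for inhibition of Nicotinamide phosphoribosyltransferase (Homo sapiens), read by WST assay, with stated times of 60 min, 5 min and 30 min, in the presence of a further agent that is not named here; a lower number here means a stronger inhibitor, a higher number a weaker inhibitor. Compound 1 gives 31.3 nM in this assay, and compound 2 gives 5.08 nM. Of the two numbers, that of compound 2 is the lower one, and the gap to compound 1 is wider than the usual scatter. Compound 1 and compound 2 differ from each other in more than one respect, so the two values cannot be traced to any single change.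

Compound 3, `O=C(/C=C/c1cccnc1)NCCCCCCc1cccc(S(=O)(=O)Nc2ccc(F)cc2)c1`, has not been measured yet. It differs from compound 2 in one respect: 4-fluorophenyl in place of 2-methylphenyl on a sulfonamide nitrogen. The rest of the molecule, including the linker and the amide end, is unchanged.

Among the compounds with values here, there is no measured pair in which only this aryl group changes, so the size of the effect is uncertain. A modest loss relative to compound 2 is expected, though one that could stay within the scatter, so that the step of a 2.0-fold higher number from compound 2 to compound 3 (0.29 log units; within the scatter) is the estimate. On that basis compound 3 is expected to give about 10 nM in this assay, with a likely range from 3 nM to 35 nM.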

Compound 3, half-maximal inhibitory concentration: 9.2 nM
Compound 3: the middle estimate sits 1.1-fold (0.04 log units) above what was measured, within the range that was stated.
By their numbers in this assay, from the lowest: compounds 2 and 3 (each within the scatter of the next); then compound 1.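

Within the data shown here, this pair gives the first direct reading of this position, since the earlier two compounds differ in more than one respect. In this assay the exchange of 2-methylphenyl for 4-fluorophenyl on a sulfonamide nitrogen gives a 1.8-fold higher number from compound 2 to compound 3 (0.26 log units; within the scatter) and so the two aryl groups cannot be told apart here: this position accepts either one with no change that exceeds the scatter of repeat measurements. Nothing available explains this result, and no separate measurement bears on it.

The swap alters two things at once, both the substituent (methyl or fluorine) and where it sits on the ring, so the compounds shown leave open whether either matters alone, a question that 4-methylphenyl and 2-fluorophenyl would help to settle. Also open, on these data alone, is how far this tolerance extends, since both groups are small, uncharged aryl rings with no hydrogen-bond donors or acceptors, and a 4-aminophenyl or a 4-carboxyphenyl group at the same place would test a very different kind of substituent.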